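A few compounds are considered here, and "the series" means these few. Any claim that something is new, unique, unknown or untested is made for them only; others in the source may bear on it.

Measured so far:
compound 1, `CC(=O)c1cccc(OCc2ccc(F)cc2)c1`, 49.6%
compound 2, `CC(=O)c1cccc(OCc2ccc(C)cc2)c1`, 23%

Of the compounds shown here, two have been tested in an assay on isolated protein for inhibition of Amine oxidase [flavin-containing] A (Homo sapiens), read by Amplex Red, with a stated time of 15 min, tested at 100 uM; on this read-out higher numbers stand for more inhibition at the one concentration tested (going by the name of the read-out) and lower numbers for less inhibition. Compound 1 `CC(=O)c1cccc(OCc2ccc(F)cc2)c1` gives 49.6%. For the measured compounds named here, compound 2 `CC(=O)c1cccc(OCc2ccc(C)cc2)c1` gives 23%, the lower of the two numbers: the one step measured, a number 26.6 percentage points lower from compound 1 to compound 2 (beyond the scatter), is beyond the scatter. Compound 3 `CC(=O)c1cccc(OCc2ccc(C(F)(F)F)cc2)c1` has not been measured. It differs from compound 2 in one place, (trifluoromethyl in place of methyl on an aromatic carbon). Going by the values given here, no measured step swaps methyl for trifluoromethyl, so the single known step only shows that changing the group at this carbon can shift the read-out by a modest amount in either direction; nothing shows which way trifluoromethyl goes. The step expected from this change, a number 9 percentage points higher from compound 2 to compound 3 (within the scatter), is therefore estimated as none beyond the scatter. For compound 3 the expected value in this assay is 32%, with a range from 8% to 58%.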

Compound 3, a percentage reported as inhibition, at one concentration (the size of the read-out at that concentration, not a potency): 27.2%
Estimate against measurement, compound 3: 4.8 percentage points above; measured number inside the range.
By their numbers in this assay, from the lowest: compounds 2 and 3 (each within the scatter of the next); then compound 1.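

In this assay, the step to trifluoromethyl, a number 4.2 percentage points higher from compound 2 to compound 3 (within the scatter), shows that at this aromatic carbon a group of four heavy atoms cannot be told apart from methyl, a group of one heavy atom. The other new step, a number 22.4 percentage points lower from compound 1 to compound 3 (beyond the scatter), sets fluoro apart from a second group, so the earlier fall from compound 1 is not particular to methyl: among these three compounds, only compound 1, with fluoro, stands apart from the others. Nothing measured here accounts for that gap.

Still open, on these data alone, is how a chlorine atom, a methoxy group or an amine would read at this same carbon. The compounds shown also leave open whether fluoro would keep its higher number on a different carbon of that ring.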